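A few compounds are considered here, and "the series" means these few. Any claim that something is new, unique, unknown or untested is made for them only; others in the source may bear on it.

Working notes on the hydrazone series. In an assay on liver (Sus scrofa) for inhibition of glucose-6-phosphatase catalytic subunit 1 (Homo sapiens), using microsomes (on this read-out higher numbers stand for weaker inhibition and lower numbers for stronger inhibition), compound 1, `C/C(=N\N(Cc1ccccc1)Cc1ccccc1)c1ccccc1`, gives 25000 nM. Compound 2, `COc1ccc2c(c1)CCC/C2=N\N(Cc1ccccc1)Cc1ccccc1`, returns only a limit of the assay in this assay, > 50000 nM, as recorded in the limit of > 50000 nM in this assay, at which 1 of the 3 values shown sits. Compound 3, `COc1ccccc1/C=N/N(Cc1ccccc1)Cc1ccccc1`, likewise reaches only a limit in this assay, > 100000 nM, as recorded in the limit of > 100000 nM in this assay, at which 1 of the 3 values shown sits. So compound 3 stands at the far weak end of the numbers shown, and no measured number is known for it; of the three values shown, two are limits and only compound 1 has a measured figure.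

The next compound, compound 4, `C(=N/N(Cc1ccccc1)Cc1ccccc1)\c1cccs1`, carries thiophen-2-yl in place of 2-methoxyphenyl on a carbon with a double bond to nitrogen. Going by the values given here, no step between measured compounds is available to calibrate this change. Since compound 3 sits at a limit, the direction of the step can only be toward stronger inhibition or none beyond the scatter; a modest gain is expected, an at least 1.1-fold lower number from compound 3 to compound 4 (0.04 log units; that floor lies within the scatter), with a real chance of another limit. Compound 4 is estimated at 90000 nM in this assay, within 25000 nM to 300000 nM.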

Compound 4, half-maximal inhibitory concentration: 1500 nM
Compound 4: middle estimate off by 60-fold (1.78 log units), on the high side; measured number outside the range, below it.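

Going by these compounds alone, the exchange of 2-methoxyphenyl for thiophen-2-yl on a carbon with a double bond to nitrogen gives the first readable step in this assay, with an at least 66-fold lower number from compound 3 to compound 4 (1.82 log units; beyond the scatter). Within the data shown here, the group on this carbon can therefore move the read-out a long way, which the earlier compounds, with no step between them, could not show. The size of the step is only a floor, because compound 3 stands at a limit of the assay and not at a number: the limit of > 100000 nM in this assay, at which 1 of the 4 values shown sits.

Going by these compounds, whether the gain follows the sulfur, the ring size or the loss of the methoxy stays open, as does how an unsubstituted phenyl or furan-2-yl would read on this carbon. Also open, on these data alone, is whether an amine or a carboxylic acid on the thiophen-2-yl ring would keep the level of compound 4, 1500 nM.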